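A few compounds are considered here, and "the series" means these few. Any claim that something is new, unique, unknown or untested is made for them only; others in the source may bear on it.

Compound 1 `CCc1cccc(NC(=O)CN2CCN(c3ccccn3)CC2)c1` and compound 2 `Cc1cccc(NC(=O)CN2CCN(c3cccc4ccccc34)CC2)c1` have both been tested in an assay on cells for agonist activity at D(4) dopamine receptor (Homo sapiens), read by luminescence and beta-arrestin recruitment, with a stated time of 90 min; a higher number here means a larger maximal response, a lower number a smaller maximal response. In this assay, among the compounds with values here, compound 1 gives 26.2%, the higher of the two numbers measured so far. In this assay compound 2 gives 16.4%; the gap to compound 1 lies within the usual scatter of the measurement, so the two cannot be told apart. Within the data shown here, no pair of measured compounds that differ in a single place is available, so no measured step exists to guide the next one. Compound 3 `Cc1cccc(NC(=O)CN2CCN(c3ccccn3)CC2)c1`, not yet measured, differs from compound 1 in one place: hydrogen in place of methyl on a saturated chain carbon bound to an aromatic carbon. Cut one bond further out, the change reads ethyl to methyl, 3-ethylphenyl to 3-methylphenyl. Among the measured compounds shown here, with only two values in hand and no single-point step, compound 3 is expected to sit close to compound 1, the step being a number 2.2 percentage points lower from compound 1 to compound 3 (within the scatter), not beyond the scatter. For compound 3 in this assay the estimate is 24%, with a range from 12% to 38%.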

Compound 3, largest response reached (Emax), in percent of the reference or control that the assay uses: 30.7%
For compound 3 the middle estimate is 6.7 percentage points below the measured one; measured number inside the range.
By their numbers in this assay, from the lowest: compounds 2, 1 and 3 (each within the scatter of the next, the first and the last beyond it).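

In this assay, within the data shown here, the change from 3-ethylphenyl to 3-methylphenyl provides the first measured single-place step in this set (a number 4.5 percentage points higher from compound 1 to compound 3 (within the scatter)). Removing the methyl from the saturated chain carbon bound to an aromatic carbon therefore produces no change in the maximal response that can be told apart from scatter, so ethyl and methyl are not distinguished at this position in the core of compound 1, something the earlier pair, which differs in more than one place, could not show. Nothing available bears on the reason for this result.

The compounds shown leave open whether a longer chain such as propyl, or an amine or a carboxylic acid carried on that chain, would shift the response beyond the scatter. They also leave open whether replacing the whole alkyl group with hydrogen would do so.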